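Shortening the amine-bearing chain on a urea-linked quinazoline scaffold

A few compounds are considered here, and "the series" means these few. Any claim that something is new, unique, unknown or untested is made for them only; others in the source may bear on it.

Compound 1 `CN(C)CCCNc1nc(-c2ccc(NC(=O)Nc3ccccc3Cl)cc2)nc2ccsc12` is the starting point. In a functional assay on MKN-45 cells (Homo sapiens) for cytotoxicity, read by MTT assay, with a stated time of 72 h (on this read-out higher numbers stand for weaker inhibition and lower numbers for stronger inhibition), compound 1 gives 690 nM. For the measured compounds named here, its only measured companion is compound 2 `CN(C)CCCNc1nc(-c2ccc(NC(=O)Nc3ccccc3Cl)cc2)nc2c(Cl)c(Cl)sc12`, which carries two chlorine atoms on the shared core; in this assay compound 2 gives 1330 nM. The gap between these two numbers lies within the usual scatter of repeated measurements, so on the evidence at hand the two compounds cannot be separated.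

The new compound is compound 3 `CN(C)CCNc1nc(-c2ccc(NC(=O)Nc3ccccc3Cl)cc2)nc2ccsc12`. It differs from compound 1 in one place: dimethylamino in place of (dimethylamino)methyl on a saturated chain carbon, two bonds along the chain from a nitrogen on an aromatic ring. In plain words, the chain that links the basic amine to the nitrogen on the aromatic ring is shortened by one carbon, while the amine itself and everything else stay the same.

Going by the values given here, no measured pair in this small set shows what such a shortening does. Among the compounds with values here, with only two numbers, both within scatter of each other, there is no basis to expect a step beyond the scatter in either direction. The potency of compound 3 is therefore expected to sit near that of its parent, with the step from a 1.2-fold higher number from compound 1 to compound 3 (0.06 log units; within the scatter) estimated as small. Compound 3 is estimated at 800 nM, with a plausible range from 300 nM to 2500 nM.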

Compound 3, half-maximal inhibitory concentration: 850 nM
Estimate against measurement, compound 3: 1.1-fold (0.03 log units) below; the measured number falls inside the stated range.
By their numbers in this assay, from the lowest: compounds 1, 3 and 2 (each within the scatter of the next).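

Replacing the 3-(dimethylamino)propyl chain of compound 1 with the 2-(dimethylamino)ethyl chain of compound 3 gives a 1.2-fold higher number from compound 1 to compound 3 (0.09 log units; within the scatter) in this assay, so removing one carbon from this chain produces no change that can be told apart from the scatter. For the compounds shown here, this is the first comparison here that isolates the chain, as compound 2 differs from compound 1 on the shared core and so says nothing about this position. Nothing at hand explains why the two chains give readings this close.

Only these two chain lengths are shown, so it remains open whether a longer chain such as 4-(dimethylamino)butyl, a diethylamino group at the chain end, or a carboxylic acid in place of the amine would give a step beyond the scatter. From the compounds shown here alone, it is also open whether the 2-(dimethylamino)ethyl chain would behave the same way on the core of compound 2, with its two chlorine atoms.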